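The source may hold more compounds than are shown below. What is called first, only, known or untested is meant among the compounds shown, and "the series" means these compounds.

Working notes on the series, all read in a functional assay on HCT-116 cells (Homo sapiens) for antiproliferative activity, read by MTT assay, with a stated time of 24 h; on this read-out lower numbers stand for stronger inhibition and higher numbers for weaker inhibition. Compound 1, `COc1ccc(C(=O)/C=C/c2ccc(-c3ccccc3)cc2)c2c1C=CC(C)(C)O2`, gives > 10000 nM, which is a limit of the assay and not a number. Compound 2, `COc1ccc(C(=O)/C=C/c2ccco2)c2c1C=CC(C)(C)O2`, gives > 10000 nM, which is also a limit and not a number. For the measured compounds named here, compound 2 therefore has no numerical place, and the only other reading beside it is a limit too: the limit of > 10000 nM in this assay, at which 2 of the 2 values shown sit.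

The next compound is compound 3, `COc1ccc(C(=O)/C=C/c2ccc(Cl)cc2)c2c1C=CC(C)(C)O2`, which has 4-chlorophenyl in place of furan-2-yl on a double-bonded chain carbon bound to a double-bonded chain carbon. Going by the values given here, no step between measured compounds is available to scale this change. In this assay, no shift beyond the usual scatter is expected, and no direction can be favoured with confidence. This expectation rests on compound 2, whose reading is the limit > 10000 nM. The estimated step is a step that the limit leaves unreadable from compound 2 to compound 3. A report as a limit is the most likely outcome for the next reading. The expected value for compound 3 is 15000 nM, with an estimated range from 5000 nM to 40000 nM.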

Compound 3, half-maximal inhibitory concentration: > 10000 nM
Compound 3: a limit, no number; the forecaster's own chance of this, stated with the estimate: 70%; the middle value does not contradict the limit.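

No step can be read between compound 3 and either compound 1 or compound 2 in this assay because all three readings are limits and not numbers: the limit of > 10000 nM in this assay, at which 3 of the 3 values shown sit.

The compounds shown leave open whether 4-chlorophenyl, furan-2-yl or any other group on the shared core changes antiproliferative activity, as none gives a numerical reading.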